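The compounds below may be only part of what the source reports. "The series", "measured", "known", "first", "only" and "open" are said of these compounds alone.

Measured so far:
compound 1 `CC(C)(N)CC(=O)N[C@@H]1CCc2ccccc2N(Cc2ccc(-c3ccccc3-c3nnn(Cc4ccccc4)n3)cc2)C1=O`, 1 uM;
compound 2 `CC(O)Cn1nnc(-c2ccccc2-c2ccc(CN3C(=O)[C@H](NC(=O)CC(C)(C)N)CCc4ccccc43)cc2)n1`, 0.05 uM;
compound 3 `CC(C)(N)CC(=O)N[C@@H]1CCc2ccccc2N(Cc2ccc(-c3ccccc3S(N)(=O)=O)cc2)C1=O`, 3 uM.

In a functional assay (Pituitary gland cell) with Rattus norvegicus as the target (a lower number here means that less compound is needed, a higher number that more compound is needed for the effect), compound 1 stands second highest of the three numbers, with a 3.0-fold higher number from compound 1 to compound 3 (0.48 log units; beyond the scatter) as the nearest step and a 20-fold lower number from compound 1 to compound 2 (1.30 log units; beyond the scatter) as the furthest. Compound 4 `CC(C)(N)CC(=O)N[C@@H]1CCc2ccccc2N(Cc2ccc(-c3ccccc3-c3nnnn3CC(=O)O)cc2)C1=O` is not yet measured; it differs from compound 1 in one place: 1-(carboxymethyl)-1H-tetrazol-5-yl in place of 2-benzyl-2H-tetrazol-5-yl on an aromatic carbon. Within the data shown here, two measured steps bear on it, both changing the same aromatic position: a 20-fold lower number from compound 1 to compound 2 (1.30 log units; beyond the scatter), a large gain with a small hydroxylated chain on the tetrazole, and a 3.0-fold higher number from compound 1 to compound 3 (0.48 log units; beyond the scatter), a modest loss when the whole tetrazole is replaced. Compound 4 keeps the tetrazole and carries a short chain, so a gain is expected, smaller than that of compound 2, given by a 3.3-fold lower number from compound 1 to compound 4 (0.52 log units; beyond the scatter). Compound 4 is expected to give 0.3 uM, within 0.05 uM to 2 uM.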

Compound 4, concentration for half-maximal effect: 1 uM
Estimate against measurement, compound 4: 3.3-fold (0.52 log units) below, and the stated range covers the measured number.
By their numbers in this assay, from the lowest: compound 2; then compounds 1 and 4 (each within the scatter of the next); then compound 3.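

In this assay, keeping a tetrazole on this aromatic carbon does not by itself bring the gain of 2-(2-hydroxypropyl)-2H-tetrazol-5-yl, as a 20-fold higher number from compound 2 to compound 4 (1.30 log units; beyond the scatter) shows. Exchanging 2-benzyl-2H-tetrazol-5-yl for 1-(carboxymethyl)-1H-tetrazol-5-yl gives no change at the digits printed from compound 1 to compound 4 (within the scatter), so the smaller group matches benzyl here, and sulfamoyl remains behind, with a 3.0-fold lower number from compound 3 to compound 4 (0.48 log units; beyond the scatter) in favour of the tetrazole. No measured evidence accounts for these steps.

Open, from the compounds shown here alone, is whether the carboxylic acid or its attachment on the tetrazole nitrogen sets the gap to compound 2, as both change at once. A 2-(carboxymethyl)-2H-tetrazol-5-yl group would separate the two.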